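Trimming the amide side chain of a chemokine receptor antagonist

The compounds below may be only part of what the source reports. "The series", "measured", "known", "first", "only" and "open" are said of these compounds alone.

Measured compounds:
- compound 1, `C[C@H]1CN(c2ncc(C(=O)NCc3ccc(F)c(F)c3)cc2Cl)CCN1C1CCN(Cc2ccc(Cl)cc2)CC1`: in a functional assay for antagonist activity at C-X-C chemokine receptor type 3 (Homo sapiens) (a higher number here means a weaker inhibitor, a lower number a stronger inhibitor), compound 1 gives 6 nM
- compound 2, `CC1CN(C2CCN(Cc3ccc(Cl)cc3)CC2)CCN1c1ccc(C(=O)NCc2ccc(F)c(F)c2)cn1`: in this assay compound 2 gives 2700 nM

Compound 1 has the lowest of the two numbers, so it is the stronger inhibitor of the pair, and the gap to compound 2 is well beyond the usual scatter. Compound 2 differs from compound 1 in more than one place, so no single change can be tied to that gap.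

Compound 3, `CC(=O)Nc1cnc(N2CCN(C3CCN(Cc4ccc(Cl)cc4)CC3)[C@@H](C)C2)c(Cl)c1`, is built from compound 1 by one change: acetamido in place of (3,4-difluorobenzyl)carbamoyl on an aromatic carbon. The whole benzyl amide arm, including its ring, is cut away and only a small acetamido group remains at the same position on the shared core.

Among the measured compounds shown here, nothing among the measured compounds shows what this arm contributes on its own. Given how much of the molecule is removed, a large step toward weaker inhibition is expected, well beyond the scatter, though it need not be as large as the gap to compound 2. Compound 3 is therefore estimated at 600 nM, with a likely range from 60 nM to 6000 nM, corresponding to an expected step of a 100-fold higher number from compound 1 to compound 3 (2.00 log units; beyond the scatter).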

Compound 3, half-maximal inhibitory concentration: 8 nM
Compound 3: middle estimate off by 75-fold (1.88 log units), on the high side; the whole stated range lies above it.
By their numbers in this assay, from the lowest: compounds 1 and 3 (each within the scatter of the next); then compound 2.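

In this assay the change from (3,4-difluorobenzyl)carbamoyl to acetamido gives a 1.3-fold higher number from compound 1 to compound 3 (0.12 log units; within the scatter), so the two compounds cannot be told apart. At this position, on an aromatic carbon para to a large group, an arm of 12 heavy atoms with its fluorinated aromatic ring can thus give way to a group of 4 heavy atoms with no ring, and strong inhibition remains; in this pair, neither the ring nor the fluorine atoms are required for it. Nothing measured here gives a reason for this tolerance.

Both groups count one hydrogen-bond donor and one hydrogen-bond acceptor, so the compounds shown leave open whether the amide they share matters at this position or whether almost any small group would do. Going by these compounds, a plain amine, a carboxylic acid or a longer chain such as butanamido at the same place would help to separate these possibilities, and what the chloro group contributes also remains unknown.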